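Swapping an acetyl for a tosyl on a sugar scaffold

The source may hold more compounds than are shown below. What is called first, only, known or untested is meant among the compounds shown, and "the series" means these compounds.

In a functional assay on HeLa cells (Homo sapiens) for antiproliferative activity, read by sulforhodamine B assay, with a stated time of 48 h (a higher number here means a weaker inhibitor of growth, a lower number a stronger inhibitor of growth), compound 1 `CC1(C)O[C@H]2[C@H](OCc3noc(-c4ccc([N+](=O)[O-])cc4)n3)O[C@H](CSc3ncn[nH]3)[C@H]2O1` gives 89000 nM and compound 3 `CC1(C)O[C@H]2[C@H](OCc3noc(-c4ccc([N+](=O)[O-])cc4)n3)O[C@H](CO)[C@H]2O1` gives 99000 nM; the change from compound 1 to compound 3 is a 1.1-fold higher number from compound 1 to compound 3 (0.05 log units; within the scatter). Compound 2 `CC(=O)OC[C@H]1O[C@@H](OCc2noc(-c3ccc([N+](=O)[O-])cc3)n2)[C@@H]2OC3(CCCC3)O[C@@H]21` gives 17000 nM, the lowest of the three numbers, beyond the scatter from both others. Compound 4 `Cc1ccc(S(=O)(=O)OC[C@H]2O[C@@H](OCc3noc(-c4ccc([N+](=O)[O-])cc4)n3)[C@@H]3OC4(CCCC4)O[C@@H]32)cc1` differs from compound 2 by (4-methylphenyl)sulfonyl in place of acetyl on an oxygen on a saturated carbon. Within the data shown here, no measured step concerns this oxygen, and the only measured step, from compound 1 to compound 3, changes a different place and is within the scatter, so it gives little guidance. The step from compound 2 to compound 4 in this assay is therefore expected to be small, a 1.4-fold lower number from compound 2 to compound 4 (0.15 log units; within the scatter), with a wide range. Compound 4 is estimated at 12000 nM, between 3000 nM and 50000 nM.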

Compound 4, concentration for 50% growth inhibition: > 100000 nM
Compound 4 was reported as a limit; the forecaster's own chance of this, stated with the estimate: 5%; middle value at least 8.3-fold (0.92 log units) away from the limit.
By their numbers in this assay, from the lowest: compound 2; then compounds 1 and 3 (each within the scatter of the next). At a limit, above all of these: compound 4.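

The oxygen on a saturated carbon is a place where the group matters: with (4-methylphenyl)sulfonyl in place of acetyl, this assay shows an at least 5.8-fold higher number from compound 2 to compound 4 (0.76 log units; beyond the scatter). The value of compound 4, > 100000 nM, is a limit of the assay and not a number. The only earlier step, at a different place, was a 1.1-fold higher number from compound 1 to compound 3 (0.05 log units; within the scatter), so this is the first change shown to move the number beyond the scatter.

The compounds shown leave open how a methanesulfonyl or an amine would read at this place. Whether the weaker growth inhibition goes with the sulfonyl or with the aromatic ring therefore stays unresolved.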